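Piperidine in Place of Morpholine on a Chromone Dithiocarbamate

The compounds below may be only part of what the source reports. "The series", "measured", "known", "first", "only" and "open" are said of these compounds alone.

Of the compounds shown here, three sharing one core have been tested in a functional assay on LM7 cells (Homo sapiens) for antiproliferative activity, read by MTT assay, with a stated time of 72 h; on this read-out higher numbers stand for weaker inhibition and lower numbers for stronger inhibition. Compound 1 `O=c1cc(CSC(=S)N2CCCCC2)oc2cc(Cl)ccc12` carries a chlorine on the shared core and gives 13800 nM. Compound 2 `COc1ccc2oc(CSC(=S)N3CCCCC3)cc(=O)c2c1` carries a methoxy group instead and gives 5000 nM. Compound 3 `O=c1cc(CSC(=S)N2CCOCC2)oc2ccccc12`, which has an unsubstituted core and a morpholin-4-yl group on the thiocarbonyl carbon, gives 25200 nM. Among these three numbers, the value of compound 3 lies furthest up; its gap to compound 2 goes beyond the usual scatter, whereas its gap to compound 1 stays within it, so no ordering of compound 3 against compound 1 can be read from the data.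

Compound 4 `O=c1cc(CSC(=S)N2CCCCC2)oc2ccccc12` is the next compound and has not yet been measured in this assay. It differs from compound 3 in one place: piperidin-1-yl in place of morpholin-4-yl on a thiocarbonyl carbon. Both compound 1 and compound 2 carry the same piperidin-1-yl group and give lower numbers than compound 3, which is the only basis for an expectation here. The step of a 2.5-fold lower number from compound 3 to compound 4 (0.40 log units; beyond the scatter) is estimated to run downward, by an amount that should exceed the scatter. Compound 4 is accordingly expected to give about 10000 nM, within a range from 4000 nM to 28000 nM.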

Compound 4, half-maximal inhibitory concentration: > 25000 nM
Compound 4: no number, only a limit; the forecaster's own chance of this, stated with the estimate: 10%; middle value at least 2.5-fold (0.39 log units) away from the limit.
By their numbers in this assay, from the lowest: compound 2; then compounds 1 and 3 (each within the scatter of the next).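

In this assay, for the compounds shown here, compound 4 gives > 25000 nM, which is a limit of the assay and not a number, so the step for piperidin-1-yl in place of morpholin-4-yl on a thiocarbonyl carbon, the only one that isolates this change, cannot be read: the limit of > 25000 nM in this assay, at which 1 of the 4 values shown sits. What the result adds lies elsewhere, with piperidin-1-yl held fixed, since hydrogen in place of methoxy on an aromatic carbon gives an at least 5.0-fold higher number from compound 2 to compound 4 (0.69 log units; beyond the scatter), which shows that the methoxy group of compound 2 goes with a real gain and that piperidin-1-yl alone does not bring compound 4 down to that level. Hydrogen in place of chloro on an aromatic carbon gives an at least 1.8-fold higher number from compound 1 to compound 4 (0.25 log units; that floor lies within the scatter), and as that floor lies within the scatter, no effect of the chlorine can be claimed.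

On these data alone, whether piperidin-1-yl differs at all from morpholin-4-yl on the unsubstituted core stays open, as does the behaviour of a pyrrolidin-1-yl or diethylamino group at that thiocarbonyl carbon. Equally open, as far as these compounds go, is whether a hydroxy or fluoro group on an aromatic carbon would follow methoxy or chloro.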